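The source may report more compounds than this note shows. Statements on the series, on what has been measured and on what is new or still open speak of the compounds shown alone.

Measured so far:
compound 1 `CC(C)N(Cc1cccc(OCCCCCC(=O)O)c1)C(=O)c1ccc(-c2cccc(-c3ccccc3)c2)cc1` – > 26000 nM
compound 2 `CC(C)N(Cc1cccc(OCCCCCC(=O)O)c1)C(=O)c1ccc(-c2ccsc2)cc1` – > 26000 nM

In an ADME assay on Raji cells (Homo sapiens) for cytotoxicity, read by CellTiter-Glo and resazurin assay, with a stated time of 72 h (on this read-out lower numbers stand for an effect already at smaller amounts and higher numbers for an effect only at larger amounts of compound), compound 1 reaches only > 26000 nM, which is a limit of the assay and not a number. Compound 2 likewise reaches only > 26000 nM, again a limit. The step that the two limits leave unreadable from compound 1 to compound 2 therefore cannot be read in either direction. Compound 2 thus stands at the edge of what this assay can report, and the limit of > 26000 nM in this assay, at which 2 of the 2 values shown sit, shows that both values sit at the same limit.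

Compound 3 `CC(C)N(Cc1cccc(OCCCCCC(=O)O)c1)C(=O)c1ccc(-c2ccc3[nH]ccc3c2)cc1` differs from compound 2 in one place: 1H-indol-5-yl in place of thiophen-3-yl on an aromatic carbon. For the measured compounds named here, the only measured step that touches this part of the molecule is unreadable, so no size of step can be drawn from it, and no shift beyond the scatter is expected in this assay. Compound 3 is therefore expected to give about 30000 nM, with a range from 10000 nM to 100000 nM. The step this estimate means is expected to be a step that the limit leaves unreadable from compound 2 to compound 3.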

Compound 3, half-maximal effective concentration: > 26000 nM
Compound 3: no number, only a limit; the forecaster's own chance of this, stated with the estimate: 80%; the middle value lies beyond the limit too.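

No step among compound 1, compound 2 and compound 3 can be read, as all three give only a limit and not a number in this assay: the limit of > 26000 nM in this assay, at which 3 of the 3 values shown sit.

The compounds shown leave open how far apart these three groups on the aromatic carbon really lie, and whether any such group gives a readable value in this assay.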